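The compounds below may be only part of what the source reports. "The series", "measured", "known", "first", "only" and "open" are said of these compounds alone.

Measured so far in a functional assay on DU-145 cells (Homo sapiens) for inhibition, read by trypan blue exclusion, with a stated time of 96 h; a higher number here means a weaker inhibitor of growth, a lower number a stronger inhibitor of growth:

compound 1 `O=C(/C(=C\c1cccc(Cl)c1Cl)SCc1ccc(Cl)cc1)c1ccc(Cl)cc1`: 10000 nM
compound 2 `CN(C)c1ccc(/C=C(/SCc2ccc(Cl)c(Cl)c2)C(=O)c2ccc(Cl)cc2)cc1`: 50000 nM
compound 3 `O=C(/C(=C\c1ccc[nH]1)SCc1ccc(Cl)cc1)c1ccc(Cl)cc1`: 10000 nM

Compound 3 stands level with compound 1 at the digits shown, and the two together give the lowest numbers of the three; compound 2 sits clearly higher than compound 3, beyond the scatter. Going by the values given here, the one single-point step measured so far, no change at the digits printed from compound 1 to compound 3 (within the scatter), shows that swapping the aryl group on this position of the chain left the read-out unchanged.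

Compound 4 `CN(C)c1ccc(/C=C(/SCc2ccc(Cl)cc2)C(=O)c2ccc(Cl)cc2)cc1` is the next member. Its change from compound 3 is 4-(dimethylamino)phenyl in place of 1H-pyrrol-2-yl on a double-bonded chain carbon bound to a double-bonded chain carbon. Among the compounds with values here, only one measured step touches the same position, and that step was flat, so on that evidence alone no movement would be expected. Compound 2, however, already carries 4-(dimethylamino)phenyl at this position and is the weakest of the three in this assay, though compound 2 also differs from compound 4 in a second place, so its value can only be taken as a hint. Weighing the flat step against that hint, compound 4 is expected to come in somewhat weaker than compound 3, with an estimated step of a 3.0-fold higher number from compound 3 to compound 4 (0.48 log units; beyond the scatter). The estimate for compound 4 in this assay is 30000 nM, within a range of 10000 nM to 100000 nM.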

Compound 4, concentration for 50% growth inhibition: > 100000 nM
Compound 4 gave a limit, no number (the forecaster's own chance of this, stated with the estimate: 25%); middle value at least 3.3-fold (0.52 log units) away from the limit.
By their numbers in this assay, from the lowest: compounds 1 and 3 (each within the scatter of the next); then compound 2. At a limit, above all of these: compound 4.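

In this assay, compound 4 gives only a limit and not a number, and it sits alone at that limit: the limit of > 100000 nM in this assay, at which 1 of the 4 values shown sits.

The earlier flat step, no change at the digits printed from compound 1 to compound 3 (within the scatter), suggested that this place on a double-bonded chain carbon bound to a double-bonded chain carbon was indifferent to the group it carries, but 4-(dimethylamino)phenyl breaks that reading, with an at least 10-fold higher number from compound 3 to compound 4 (1.00 log units; beyond the scatter) and an at least 10-fold higher number from compound 1 to compound 4 (1.00 log units; beyond the scatter), both beyond the scatter. The other new step, hydrogen in place of chloro on an aromatic carbon, reads an at least 2.0-fold higher number from compound 2 to compound 4 (0.30 log units; that floor lies within the scatter), and that floor lies within the scatter, so the chloro change with 4-(dimethylamino)phenyl in place shows no firm effect, though its true size may be larger.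

Going by these compounds, because compound 4 is a limit, the full size of all three steps stays open. On these data alone, whether the change follows the dimethylamino group or the six-membered aromatic ring that carries it also stays open, and a plain phenyl or a 4-aminophenyl at this place would separate the two.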